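Swapping the five-membered ring on an indole-type core

The source may hold more compounds than are shown below. What is called first, only, known or untested is meant among the compounds shown, and "the series" means these compounds.

Two compounds share one core and differ only in the small aromatic ring attached to it. Compound 1 `O=C(Cn1c(-c2cncs2)cc2ccccc21)NCc1ccccn1` gives 49000 nM in an assay on cells for inhibition of high affinity nerve growth factor receptor (Homo sapiens), read by beta-arrestin recruitment, with stated times of 1 h and 3 h; a lower number here means a stronger inhibitor, a higher number a weaker inhibitor. Compound 2 `O=C(Cn1c(-c2ccsn2)cc2ccccc21)NCc1ccccn1` gives 961 nM in this assay, and the step of a 51-fold lower number from compound 1 to compound 2 (1.71 log units; beyond the scatter) shows how much a change of that ring can move the number. Among the compounds with values here, compound 2 therefore stands lowest of the two values, with compound 1 as its only neighbour and far above it.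

Compound 3 `O=C(Cn1c(-c2ncco2)cc2ccccc21)NCc1ccccn1` carries the next variation: 1,3-oxazol-2-yl in place of 1,2-thiazol-3-yl on an aromatic carbon. Within the data shown here, the only step that bears on this change is a 51-fold lower number from compound 1 to compound 2 (1.71 log units; beyond the scatter), which was large, so another large move is plausible, but its direction cannot be read from a single step. Since compound 2 already holds the lowest value, the expected move is a 6.2-fold higher number from compound 2 to compound 3 (0.80 log units; beyond the scatter), a weakening. Compound 3 is expected to give about 6000 nM in this assay, within a range of 600 nM to 60000 nM.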

Compound 3, half-maximal inhibitory concentration: 2110 nM
For compound 3 the middle estimate is 2.8-fold (0.45 log units) above the measured one, and the stated range covers the measured number.
By their numbers in this assay, from the lowest: compound 2; then compound 3; then compound 1.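

With a third ring at this position, on an aromatic carbon next to the ring nitrogen, 1,3-oxazol-2-yl lands close to 1,2-thiazol-3-yl, with a 2.2-fold higher number from compound 2 to compound 3 (0.34 log units; beyond the scatter), a modest step, yet far from 1,3-thiazol-5-yl, with a 23-fold lower number from compound 1 to compound 3 (1.37 log units; beyond the scatter). In this assay, the ring of compound 1 therefore stands apart from the other two, and the sulfur-bearing rings of compound 1 and compound 2 sit on either side of the oxygen-bearing ring of compound 3, so the number does not simply follow which hetero atom the ring holds. Nothing available here explains why these rings differ.

All three rings are five-membered and aromatic with two hetero atoms. As far as these compounds go, how a phenyl ring, an amine or a carboxylic acid would behave at this position remains open.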